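Swapping the aryl group on a potent antiproliferative compound

This account rests on a few compounds, and the source may have more. Where it says the series, first, only, none or still open, it means among the compounds named here.

In a functional assay on CCRF-CEM cells (Homo sapiens) for antiproliferative activity (on this read-out higher numbers stand for weaker inhibition and lower numbers for stronger inhibition), compound 1 (`COc1cc(C(=O)c2sc(-c3ccc(-c4ccccc4)cc3)cc2N)cc(OC)c1OC`) gives > 10000 nM, which is a limit of the assay and not a number. Going by the values given here, compound 2 (`COc1ccc(-c2cc(N)c(C(=O)c3cc(OC)c(OC)c(OC)c3)s2)cc1OC`) gives 20 nM, the only true number available so far. These two values show that compounds sharing a core can sit very far apart on this read-out.

Compound 3 (`COc1cc(C(=O)c2sc(-c3ccc([N+](=O)[O-])cc3)cc2N)cc(OC)c1OC`) is reached from compound 2 by one change: 4-nitrophenyl in place of 3,4-dimethoxyphenyl on an aromatic carbon, next to the ring sulfur (4-nitrophenyl in place of 3,4-dimethoxyphenyl on an aromatic carbon). Among the compounds with values here, no measured pair of compounds differs in just one place, so the size of this step cannot be read from a direct precedent. Since compound 2 stands at 20 nM, there is plenty of room for activity to fall, and the wide gap within this small set argues against assuming the change is harmless. In this assay, the expected step is a 25-fold higher number from compound 2 to compound 3 (1.40 log units; beyond the scatter), toward weaker inhibition and beyond the usual scatter. For compound 3 the estimated value is 500 nM, with an expected range from 50 nM to 8000 nM.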

Compound 3, half-maximal inhibitory concentration: 99 nM
The estimate for compound 3 lay 5.1-fold (0.70 log units) above the measured number; measured number inside the range.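

In this assay, the aryl group on the aromatic carbon next to the ring sulfur can be exchanged for a very different one and the compound stays active, with the step of a 5.0-fold higher number from compound 2 to compound 3 (0.69 log units; beyond the scatter) costing some activity but leaving compound 3 far from inactive. The second new comparison, with nitro in place of phenyl on an aromatic carbon, shows that the group carried on this aryl ring can matter much more than that: an at least 100-fold lower number from compound 1 to compound 3 (2.00 log units; beyond the scatter). Compound 1 gives > 10000 nM, which is a limit of the assay and not a number, so this step sets only a minimum for the true gap: the limit of > 10000 nM in this assay, at which 1 of the 3 values shown sits.

Compounds 2 and 3 differ in a whole aryl group, so the loss of activity cannot be assigned to the removal of the two methoxy groups or to the arrival of the nitro group. As far as these compounds go, how a plain phenyl, a 4-methoxyphenyl or a 4-aminophenyl in this place would compare with compound 2 and compound 3 remains open, as does whether any group here can match or better compound 2.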